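Replacing Carboxy with Chloro: Expected Drop in Solubility

A few compounds are considered here, and "the series" means these few. Any claim that something is new, unique, unknown or untested is made for them only; others in the source may bear on it.

Three urea compounds built on one shared core have been measured in a physicochemical assay for solubility, at pH 7.4; on this read-out lower numbers stand for lower solubility and higher numbers for higher solubility. Compound 1, `Cc1cc(NC(=O)Nc2ccc(C(=O)O)cc2)c2ccccc2n1`, carries a carboxy group on its outer aromatic ring and gives 9300 nM, the highest of the three numbers. Compound 2, `Cc1cc(NC(=O)Nc2ccccc2C(F)(F)F)c2ccccc2n1`, gives 3800 nM in this assay, a gap beyond the scatter below compound 1. Compound 3, `Cc1cc(NC(=O)Nc2cccc(C(F)(F)F)c2)c2ccccc2n1`, gives 100 nM, far below both others. Compound 1 therefore stands alone at the top of this small set.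

Compound 4, `Cc1cc(NC(=O)Nc2ccc(Cl)cc2)c2ccccc2n1`, has not yet been measured. It differs from compound 1 in a single place: chloro in place of carboxy on an aromatic carbon. The group that leaves brought one hydrogen-bond donor and one hydrogen-bond acceptor; the chloro that enters brings none.

Among the compounds with values here, no measured pair shows exactly this change, so the expectation rests on what the set shows. The two compounds lacking the carboxy, compound 2 at 3800 nM and compound 3 at 100 nM, both sit below compound 1, the latter by a wide margin. A drop beyond the scatter is therefore expected for compound 4. The expected step is a 23-fold lower number from compound 1 to compound 4 (1.37 log units; beyond the scatter), downward. Compound 4 is estimated at 400 nM, with a likely range from 60 nM to 2500 nM.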

Compound 4, solubility: 1400 nM
Compound 4: middle estimate off by 3.5-fold (0.54 log units), on the low side; low and high end bracket the measured number.
By their numbers in this assay, from the lowest: compound 3; then compound 4; then compound 2; then compound 1.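

Within the data shown here, this is the first pair in the set that differs in one place only, so a single swap can be read directly in this assay: chloro in place of carboxy on an aromatic carbon, para to a large group, gives a 6.6-fold lower number from compound 1 to compound 4 (0.82 log units; beyond the scatter) as a modest step beyond the scatter. At this position, then, the carboxy can be exchanged for a smaller group with no hydrogen-bond donor or acceptor while compound 4 still reads 1400 nM in this assay. No measurement at hand explains why the step has this size.

The compounds shown leave open how much of the step belongs to the carboxy leaving and how much to the chloro entering, and a plain hydrogen on the same carbon would help separate the two. An amine, a methyl or a trifluoromethyl on that carbon would also show whether other replacements for the carboxy give a step of similar size, or whether chloro behaves differently from them.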